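The source may hold more compounds than are shown below. What is called first, only, known or untested is meant among the compounds shown, and "the series" means these compounds.

For the measured compounds named here, compound 2 `Cc1nc(-c2ccc(F)cc2)sc1COc1ccc(OCC(=O)O)c(F)c1` is one of only two compounds tested in an assay on CHO cells for agonist activity at Free fatty acid receptor 1 (Homo sapiens), read by FLIPR (on this read-out lower numbers stand for an effect already at smaller amounts and higher numbers for an effect only at larger amounts of compound), and in this assay compound 2 gives 112 nM, the only numerical result available. Compound 1 `Cc1cc(OCc2sc(-c3ccc(C(F)(F)F)cc3)nc2C)ccc1OCC(=O)O` returns just a limit of the assay in this assay, namely > 10000 nM. That result sits at the limit of > 10000 nM in this assay, at which 1 of the 2 values shown sits. Compound 3 `Cc1ccc(-c2nc(C)c(COc3ccc(OCC(=O)O)c(F)c3)s2)cc1` has not yet been measured. It differs from compound 2 in one place: methyl in place of fluoro on an aromatic carbon, described as methyl in place of fluoro on an aromatic carbon. Going by the values given here, no pair of measured compounds shows what this change does, so there is no measured step to lean on. The change from compound 2 to compound 3 is expected to move the result only slightly, a 1.0-fold lower number from compound 2 to compound 3 (0.01 log units; within the scatter), in no clear direction and likely within the scatter. Compound 3 is estimated at 110 nM in this assay, with a range from 30 nM to 450 nM.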

Compound 3, half-maximal effective concentration: 156 nM
For compound 3 the middle estimate is 1.4-fold (0.15 log units) below the measured one, within the range that was stated.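

For the compounds shown here, with a 1.4-fold higher number from compound 2 to compound 3 (0.14 log units; within the scatter), this is the first measured step at this position in this assay. On the aromatic carbon para to a large group, fluoro and methyl, each a single heavy atom, cannot be told apart in this read-out, so the 4-fluorophenyl to 4-methylphenyl change leaves the result within the usual noise of the assay. Nothing measured here offers a reason for this outcome.

Going by these compounds alone, compound 1 carries trifluoromethyl in this place but gives only a limit of the assay, > 10000 nM, and it differs from compound 2 and compound 3 in more than one place, so no step to it can be read. On these data alone, what an amine or a longer chain would do in this place remains open.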